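A few compounds are considered here, and "the series" means these few. Any claim that something is new, unique, unknown or untested is made for them only; others in the source may bear on it.

Two compounds carry the shared core of compound 1 `O=C(CN(c1nc(Cl)nc2[nH]cnc12)C1CC1)N[C@@H](CO)C(=O)OCc1ccccc1` and differ only in the side chain at the saturated chain carbon. In a functional assay on the whole organism (Tail, strain ICR) with Mus musculus as the target, in the tail flick test, with a stated time of 150 min, at a dose of 25 umol/kg by the oral route (on this read-out lower numbers stand for a weaker effect and higher numbers for a stronger effect at the one dose given), compound 1 gives 27.9%. Among the compounds with values here, compound 2 `O=C(CN(c1nc(Cl)nc2[nH]cnc12)C1CC1)N[C@@H](CCC(=O)OCc1ccccc1)C(=O)OCc1ccccc1` carries the longer chain, and in this assay compound 2 gives 44.5%, the higher of the two numbers; the step of a number 16.6 percentage points higher from compound 1 to compound 2 (beyond the scatter) is the only measured step in the set. Compound 3 `NCCCC[C@H](NC(=O)CN(c1nc(Cl)nc2[nH]cnc12)C1CC1)C(=O)OCc1ccccc1` is reached from compound 2 by the change (2-aminoethyl in place of benzyloxycarbonyl on a saturated chain carbon, three bonds along the chain from an amide-type nitrogen and a carbonyl carbon). Within the data shown here, no measured step covers this change: the one step on record exchanges a hydroxy for a (benzyloxycarbonyl)methyl group, whereas here the benzyloxycarbonyl is lost and a 2-aminoethyl arrives. That one step shows that the side chain on this carbon can move the number by a modest amount, so for compound 3 a change of similar size is expected rather than none, and a downward direction is judged somewhat more likely, giving an expected step of a number 14.5 percentage points lower from compound 2 to compound 3 (beyond the scatter). Compound 3 is therefore estimated at 30%, within a range from 10% to 55%.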

Compound 3, a percentage reported as activity, at one dose (the size of the read-out at that dose, not a potency): 9.88%
Estimate against measurement, compound 3: 20.1 percentage points above; measured number below the stated range.
By their numbers in this assay, from the lowest: compound 3; then compound 1; then compound 2.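

Read in this assay, the exchange of 2-(benzyloxycarbonyl)ethyl for 4-aminobutyl gives a number 34.6 percentage points lower from compound 2 to compound 3 (beyond the scatter) and is a large step, so this saturated chain carbon can move the number further than the one earlier step showed, and downward as well as upward. The 3-aminopropyl group in place of hydroxy gives a number 18 percentage points lower from compound 1 to compound 3 (beyond the scatter) in the direction opposite to a number 16.6 percentage points higher from compound 1 to compound 2 (beyond the scatter) for the (benzyloxycarbonyl)methyl group, so replacing the hydroxy does not by itself raise the number: the outcome depends on which group arrives. Nothing among the data offered accounts for the size or direction of these steps.

The change from compound 2 to compound 3 removes the benzyloxycarbonyl group and brings in the amine together, so the compounds shown do not separate the share of each in the drop. A plain butyl chain or a 4-hydroxybutyl chain at this carbon could tell those two parts apart, and a carboxylic acid at the chain end or a shorter amine chain would show how far the effect follows the end group or the chain length.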